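Homologating the Amino Group of a Potent Antagonist

A few compounds are considered here, and "the series" means these few. Any claim that something is new, unique, unknown or untested is made for them only; others in the source may bear on it.

Compound 3: `CN(C)c1ccc(C(=O)N2CCC(n3cncc3-c3ccc(OS(=O)(=O)c4cccc5cnccc45)cc3)CC2)cc1` — 0.11 nM
Compound 2: `CS(=O)(=O)c1ccc(C(=O)N2CCC(n3cncc3-c3ccc(OS(=O)(=O)c4cccc5cnccc45)cc3)CC2)cc1` — 25 nM
Compound 1: `COc1ccc(C(=O)N2CCC(n3cncc3-c3ccc(OS(=O)(=O)c4cccc5cnccc45)cc3)CC2)cc1OC` — 259 nM

In an assay on HEK293 cells for antagonist activity at P2X purinoceptor 7 (Homo sapiens), read by fluorescence, with a stated time of 2 h (on this read-out lower numbers stand for stronger inhibition and higher numbers for weaker inhibition), compound 3 gives the lowest number of the three, with compound 2 the nearest at a 230-fold lower number from compound 2 to compound 3 (2.36 log units; beyond the scatter) and compound 1 the furthest at a 2400-fold lower number from compound 1 to compound 3 (3.37 log units; beyond the scatter). Both steps lie beyond the scatter, so compound 3 is the most potent of the measured set.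

Compound 4 is `CCN(CC)c1ccc(C(=O)N2CCC(n3cncc3-c3ccc(OS(=O)(=O)c4cccc5cnccc45)cc3)CC2)cc1`. It differs from compound 3 by diethylamino in place of dimethylamino on an aromatic carbon, on an aromatic carbon of the six-membered ring of carbon only.

Going by the values given here, no measured step changes the alkyl groups on that nitrogen. The steps of a 2400-fold lower number from compound 1 to compound 3 (3.37 log units; beyond the scatter) and a 230-fold lower number from compound 2 to compound 3 (2.36 log units; beyond the scatter) show that the dimethylamino group at this place is tied to a very large gain in this assay, while a 10-fold lower number from compound 1 to compound 2 (1.02 log units; beyond the scatter) is smaller. Since a diethylamino group keeps the same acceptor and only lengthens the chains, the expected step of a 1.8-fold higher number from compound 3 to compound 4 (0.26 log units; within the scatter) is small, likely within the scatter or a modest loss. Compound 4 is estimated at 0.2 nM, with a range from 0.04 nM to 1 nM.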

Compound 4, half-maximal inhibitory concentration: 1440 nM
Beside the measured number, compound 4's estimate is 7200-fold (3.86 log units) below it; measured number outside the range, above it.
By their numbers in this assay, from the lowest: compound 3; then compound 2; then compound 1; then compound 4.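

In this assay the change from dimethylamino to diethylamino, on an aromatic carbon para to a large group, gives a 13000-fold higher number from compound 3 to compound 4 (4.12 log units; beyond the scatter) and is the largest step in the set, so the gain seen with dimethylamino does not extend to diethylamino. Diethylamino also stands behind methylsulfonyl with a 58-fold higher number from compound 2 to compound 4 (1.76 log units; beyond the scatter) and behind the 3,4-dimethoxyphenyl variant with a 5.6-fold higher number from compound 1 to compound 4 (0.75 log units; beyond the scatter) in this series, so of the four compounds the two with an amino nitrogen at this place give both the lowest and the highest number. Nothing measured here accounts for the size of this loss.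

Going by these compounds, whether one ethyl group on the nitrogen, as in ethyl(methyl)amino, already brings the loss remains open. So does how a methylamino group or a free amine would stand at this place.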